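Extending the Bromoalkyl Chain of Compound 2

A few compounds are considered here, and "the series" means these few. Any claim that something is new, unique, unknown or untested is made for them only; others in the source may bear on it.

In a functional assay on HL-60 cells (Homo sapiens) for cytotoxicity, read by MTT assay, with a stated time of 24 h (a lower number here means a stronger inhibitor, a higher number a weaker inhibitor), compound 2 (`BrCCCCOc1c(Br)cc(Br)cc1Oc1ccc(Br)cc1Br`) gives 25.9 ug/mL. Alongside it stand compound 1 (`BrCCCOc1c(Br)cc(Br)cc1Oc1ccc(Br)cc1Br`), which gives 29.9 ug/mL, and compound 3 (`COc1ccccc1N1CCN(CCCCCOc2c(Br)cc(Br)cc2Oc2ccc(Br)cc2Br)CC1`), which carries a different group at the end of its chain and gives 32.2 ug/mL. These three values lie within the usual scatter of one another, so compound 2 holds no distinct place among them.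

The next compound to consider is compound 4 (`BrCCCCCOc1c(Br)cc(Br)cc1Oc1ccc(Br)cc1Br`). Its structure departs from that of compound 2 in one place: bromomethyl in place of bromo on a saturated chain carbon, four bonds along the chain from an oxygen on an aromatic ring. In words, this is bromomethyl in place of bromo on a saturated chain carbon, four bonds along the chain from an oxygen on an aromatic ring. The same difference, cut further out, reads 3-bromopropyl to 4-bromobutyl.

For the measured compounds named here, only one measured step bears directly on this change. It is the same kind of replacement made three bonds along the chain from an oxygen on an aromatic ring, and it amounts to a 1.2-fold lower number from compound 1 to compound 2 (0.06 log units; within the scatter). Going by these compounds, with that step as the guide, no shift beyond the scatter is expected in this assay, and the direction remains open. The expected change is a 1.1-fold higher number from compound 2 to compound 4 (0.03 log units; within the scatter). For compound 4 the estimated value is 28 ug/mL, with an expected range of 17 ug/mL to 43 ug/mL.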

Compound 4, half-maximal inhibitory concentration: 25.7 ug/mL
Beside the measured number, compound 4's estimate is 1.1-fold (0.04 log units) above it; low and high end bracket the measured number.
By their numbers in this assay, from the lowest: compounds 4, 2, 1 and 3 (each within the scatter of the next).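

In this assay the replacement of bromo by bromomethyl, now made four bonds along the chain from an oxygen on an aromatic ring, comes to a 1.0-fold lower number from compound 2 to compound 4 (0.00 log units; within the scatter) and so shows that this position, like the one three bonds along the chain, gives no shift beyond the scatter. Cut as a single larger difference, 2-bromoethyl in place of bromo three bonds along the chain, the comparison gives a 1.2-fold lower number from compound 1 to compound 4 (0.07 log units; within the scatter) and also stays inside the scatter, so the two replacements taken together do not add up to a distinct difference among these bromoalkyl compounds. Nothing measured here bears on why the numbers stay so close.

The compounds shown leave open whether a longer chain would still give a number within the scatter of these, or whether the flat picture belongs only to the short range of chains seen here. They also leave open what happens when the terminal bromo is replaced by a hydroxyl or a carboxylic acid on the same chain, since every step read so far keeps that bromine in place.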